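The source may hold more compounds than are shown below. What is called first, only, known or untested is meant among the compounds shown, and "the series" means these compounds.

Compound 1 `O=C(Nc1ccc(O)c(C(=O)O)c1)c1cccc(N2C(=O)CCS2(=O)=O)c1`: 54%
Compound 2 `O=C(Nc1ccc(C(=O)O)c(O)c1)c1ccc(N2C(=O)CCS2(=O)=O)cc1`: 100%
Compound 3 `O=C(O)c1cccc(NC(=O)c2cccc(N3C(=O)CCS3(=O)=O)c2)c1`: 5%

In an assay on isolated protein for inhibition of NAD-dependent protein deacylase sirtuin-6 (Homo sapiens), read by fluorescence, tested at 200 uM (on this read-out higher numbers stand for more inhibition at the one concentration tested (going by the name of the read-out) and lower numbers for less inhibition), compound 3 stands lowest of the three numbers. Within the data shown here, its nearest neighbour is compound 1, and the one measured step that touches it is a number 49 percentage points lower from compound 1 to compound 3 (beyond the scatter), in which a hydrogen took the place of a hydroxy on an aromatic carbon. Among the measured compounds shown here, compound 2 gives 100%, far above compound 3, but no single-point step links these two.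

Compound 4 `O=C(Cc1cccs1)Nc1cccc(C(=O)Nc2cccc(C(=O)O)c2)c1` is not yet measured. The change from compound 3 is a group of 9 heavy atoms (6 carbon, 1 nitrogen, 1 oxygen, 1 sulfur; one five-membered aromatic ring with 1 hetero atom) in place of a group of 8 heavy atoms (3 carbon, 1 nitrogen, 3 oxygen, 1 sulfur; one five-membered non-aromatic ring with 2 hetero atoms), on an aromatic carbon. For the measured compounds named here, no measured step matches this kind of change: the only step known concerns a hydroxy group elsewhere, and it says nothing about swapping one ring-bearing group for another. There is therefore no ground to expect a step beyond the scatter in either direction, though the uncertainty is wide. The expected step is a number 10 percentage points higher from compound 3 to compound 4 (within the scatter). Compound 4 is estimated to give 15% in this assay, within a range from 0% to 45%.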

Compound 4, a percentage reported as inhibition, at one concentration (the size of the read-out at that concentration, not a potency): "not active" (no number reported)
Nothing numeric was reported for compound 4, so the estimate cannot be set against anything.
By their numbers in this assay, from the lowest: compound 3; then compound 1; then compound 2.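

Among these compounds, compound 4 is reported in this assay only as "not active", without a number, so no step from compound 3 to compound 4 can be read. No other data here bear on this result. As far as these compounds go, how the (((thiophen-2-yl)methyl)carbonyl)amino group compares in size of effect with the group it replaces stays open.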